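Working notes: ether substituent, compound 2 to compound 3

This account rests on a few compounds, and the source may have more. Where it says the series, first, only, none or still open, it means among the compounds named here.

Compound 1 `O=C(NCCNS(=O)(=O)c1ccc(-c2ccccc2OCc2cccc(O)c2)s1)Nc1cc(C(F)(F)F)cc(C(F)(F)F)c1`: 3000 nM
Compound 2 `O=C(NCCNS(=O)(=O)c1ccc(-c2ccccc2Oc2ccc(O)c(O)c2)s1)Nc1cc(C(F)(F)F)cc(C(F)(F)F)c1`: 4900 nM

In a functional assay on RS4-11 cells (Homo sapiens) for inhibition, read by CCK-8 assay, with a stated time of 48 h (a lower number here means a stronger inhibitor, a higher number a weaker inhibitor), compound 2 gives 4900 nM, within the scatter of compound 1. Compound 3 `O=C(NCCNS(=O)(=O)c1ccc(-c2ccccc2OCc2ccccc2)s1)Nc1cc(C(F)(F)F)cc(C(F)(F)F)c1` differs from compound 2 by benzyl in place of 3,4-dihydroxyphenyl on an oxygen on an aromatic ring, with benzyl in place of 3,4-dihydroxyphenyl on an oxygen on an aromatic ring. For the measured compounds named here, only one measured step bears on this place, a 1.6-fold higher number from compound 1 to compound 2 (0.21 log units; within the scatter), and it lies within the scatter. Going by the values given here, no measured compound carries the plain benzyl, so the range stays wide. The step expected in this assay is a 1.4-fold lower number from compound 2 to compound 3 (0.15 log units; within the scatter), with none expected beyond the scatter. Compound 3 is estimated at 3500 nM, with an expected range of 1300 nM to 9000 nM.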

Compound 3, half-maximal inhibitory concentration: > 50000 nM
Compound 3 was reported as a limit (the forecaster's own chance of this, stated with the estimate: 3%); middle value at least 14-fold (1.15 log units) from the limit.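

In this assay this position no longer looks tolerant: the step between the two hydroxy-bearing groups stayed within the scatter, yet benzyl in place of 3,4-dihydroxyphenyl gives an at least 10-fold higher number from compound 2 to compound 3 (1.00 log units; beyond the scatter). Hydrogen in place of hydroxy alone gives an at least 16-fold higher number from compound 1 to compound 3 (1.22 log units; beyond the scatter), so among these compounds a hydroxy on this ring goes with a measurable value. The result for compound 3 is a limit: the limit of > 50000 nM in this assay, at which 1 of the 3 values shown sits.

From the compounds shown here alone, the full size of both steps stays open. So does whether an amine or a methoxy on the same ring would serve in place of the hydroxy.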